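A few compounds are considered here, and "the series" means these few. Any claim that something is new, unique, unknown or untested is made for them only; others in the source may bear on it.

Three compounds share one core and differ only in the group attached to an aromatic carbon of that core. Compound 1 `COc1cccc2c1CCC2c1ncc[nH]1` carries a methoxy group and in a functional assay on CHO cells for agonist activity at Alpha-1A adrenergic receptor (Homo sapiens), read by FLIPR and calcium flux (a higher number here means that more compound is needed for the effect, a lower number that less compound is needed), gives 32 nM. Compound 2 `Cn1nccc1-c1cccc2c1CCC2c1ncc[nH]1` carries a 1-methyl-1H-pyrazol-5-yl group in the same place and in this assay gives 278 nM. Compound 3 `c1cncc(-c2cccc3c2CCC3c2ncc[nH]2)c1` carries a pyridin-3-yl group and in this assay gives 2060 nM, the highest number of the three, so the most compound is needed for the effect. The measured steps show how strongly this position responds to a change of group: an 8.7-fold higher number from compound 1 to compound 2 (0.94 log units; beyond the scatter), a 64-fold higher number from compound 1 to compound 3 (1.81 log units; beyond the scatter) and a 7.4-fold higher number from compound 2 to compound 3 (0.87 log units; beyond the scatter).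

Compound 4 `c1cc(-c2nccs2)c2c(c1)C(c1ncc[nH]1)CC2` has not been measured. It differs from compound 3 in one place: 1,3-thiazol-2-yl in place of pyridin-3-yl on an aromatic carbon. All three measured steps bear on it, since each swaps the group at this same aromatic carbon, and each moved the number beyond the scatter. Of the measured replacements, the group in compound 2 gave the number closest to that of compound 3. A moderate fall in the number is therefore expected, the estimated step being a 5.9-fold lower number from compound 3 to compound 4 (0.77 log units; beyond the scatter). Compound 4 is expected to give about 350 nM in this assay, within a range of 100 nM to 1200 nM.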

Compound 4, half-maximal effective concentration: 426 nM
For compound 4 the middle estimate is 1.2-fold (0.09 log units) below the measured one, and the stated range covers the measured number.
By their numbers in this assay, from the lowest: compound 1; then compounds 2 and 4 (each within the scatter of the next); then compound 3.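

Replacing pyridin-3-yl with 1,3-thiazol-2-yl at this aromatic carbon lowers the amount of compound needed in this assay, with a 4.8-fold lower number from compound 3 to compound 4 (0.68 log units; beyond the scatter). This adds a second five-membered aromatic ring to the series, and the two cannot be told apart: the step of a 1.5-fold higher number from compound 2 to compound 4 (0.19 log units; within the scatter) shows that 1-methyl-1H-pyrazol-5-yl and 1,3-thiazol-2-yl, despite their different hetero atoms, give numbers within the normal spread of repeat measurements. Neither ring matches the methoxy group, as shown by a 13-fold higher number from compound 1 to compound 4 (1.12 log units; beyond the scatter), so methoxy remains the group needing the least compound among the four shown.

Nothing available here explains why these groups differ at this position. Also open, as far as these compounds go, is whether an ethoxy group or an amine at this carbon would give a number as low as methoxy, or whether another five-membered aromatic ring, such as furan-2-yl, would again fall close to compound 2 and compound 4.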